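This account rests on a few compounds, and the source may have more. Where it says the series, first, only, none or still open, it means among the compounds named here.

Compound 2 `COc1ccc(C(=O)/C=C/c2cc(-c3cc(OC)c(OC)c(OC)c3)n[nH]2)cc1OC` is a close relative of compound 1 `COc1cc(-c2cc(/C=C/C(=O)c3ccc(N)cc3)[nH]n2)cc(OC)c1OC`. Within the data shown here, in a functional assay on NCI-H522 cells (Homo sapiens) for cytotoxicity, read by sulforhodamine B assay, with a stated time of 48 h, tested at 1 uM (a lower number here means a stronger effect, a higher number a weaker effect of the compound at the concentration tested), compound 1 gives 77%, while compound 2 gives -63%, which is the lowest of the two numbers known so far. Among the measured compounds shown here, the single measured step, a number 140 percentage points lower from compound 1 to compound 2 (beyond the scatter), changed only the aromatic group attached to the carbonyl carbon and shows that this position can swing the read-out strongly. Compound 3 `COc1cc(-c2cc(/C=C/C(=O)c3ccc(F)c(F)c3)[nH]n2)cc(OC)c1OC` differs from compound 2 at the same position: 3,4-difluorophenyl in place of 3,4-dimethoxyphenyl on a carbonyl carbon. For the measured compounds named here, no measured step shows the effect of this particular exchange, so its size and direction are uncertain; the large step from compound 1 to compound 2 only warns that a sizeable move in either direction is plausible. The estimate for compound 3 is therefore cautious and wide: a value of 20%, with a range from -50% to 90%, corresponding to an expected step of a number 83 percentage points higher from compound 2 to compound 3 (beyond the scatter).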

Compound 3, a percentage reported as activity, at one concentration (the size of the read-out at that concentration, not a potency): 71%
For compound 3 the middle estimate is 51 percentage points below the measured one; measured number inside the range.
By their numbers in this assay, from the lowest: compound 2; then compounds 3 and 1 (each within the scatter of the next).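

Putting 3,4-difluorophenyl in place of 3,4-dimethoxyphenyl on the carbonyl carbon gives, in this assay, a number 134 percentage points higher from compound 2 to compound 3 (beyond the scatter) and so removes the strong effect seen with the dimethoxy group. Set against 4-aminophenyl, the same group gives a number 6 percentage points lower from compound 1 to compound 3 (within the scatter), so two differently substituted phenyl groups leave the read-out at a similar level, and only the 3,4-dimethoxyphenyl group of compound 2 stands apart among these three compounds. Nothing available explains why this one group differs from the other two.

The compounds shown leave open whether compound 2 needs both of its methoxy groups. A phenyl group carrying a single methoxy group, or one carrying ethoxy groups instead, would show how narrowly the strong effect depends on the 3,4-dimethoxyphenyl group.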